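Carboxylic acid to pyrrolidine amide on a macrocyclic core

A few compounds are considered here, and "the series" means these few. Any claim that something is new, unique, unknown or untested is made for them only; others in the source may bear on it.

In a functional assay on MCF7 cells (Homo sapiens) for antiproliferative activity, read by MTT assay, with a stated time of 48 h (on this read-out lower numbers stand for stronger inhibition and higher numbers for weaker inhibition), compound 1 `CC(C)=CCC[C@]1(C)/C=C/[C@@H](OC(=O)C=C(C)C)[C@](C)(O)/C=C/C(=O)/C(C(=O)O)=C\C1` gives 16100 nM. It stands at the highest of the three numbers measured, but its neighbours sit close: compound 2 `CC(C)=CCC[C@]1(C)/C=C/[C@@H](OC(=O)C=C(C)C)[C@](C)(O)/C=C/C(=O)/C(C[Si](c2ccccc2)(c2ccccc2)C(C)(C)C)=C\C1` gives 15800 nM and compound 3 `CC(C)=CCC[C@](C)(/C=C/[C@@H](OC(=O)C=C(C)C)[C@](C)(O)/C=C/C(=O)/C=C/N(C)C)CC=O` gives 12200 nM, both within the usual scatter of compound 1. For the measured compounds named here, no step between compounds that differ in a single place has been measured here, so nothing shows yet how a change at one position of this core moves this assay.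

Compound 4 `CC(C)=CCC[C@]1(C)/C=C/[C@@H](OC(=O)C=C(C)C)[C@](C)(O)/C=C/C(=O)/C(C(=O)N2CCCC2)=C\C1` differs from compound 1 in one place: pyrrolidin-1-yl in place of hydroxy on a carbonyl carbon. Cut one bond further out, the difference reads carboxy to (pyrrolidin-1-yl)carbonyl.

Going by the values given here, with no measured step to lean on, the expected step from compound 1 to compound 4 is small, a 1.5-fold lower number from compound 1 to compound 4 (0.17 log units; within the scatter), leaning toward a lower number but not with confidence beyond the scatter. Compound 4 is therefore estimated at 11000 nM in this assay, with a range from 3500 nM to 35000 nM.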

Compound 4, half-maximal inhibitory concentration: 17200 nM
For compound 4 the middle estimate is 1.6-fold (0.19 log units) below the measured one; measured number inside the range.
By their numbers in this assay, from the lowest: compounds 3, 2, 1 and 4 (each within the scatter of the next).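

In this assay, for the compounds shown here, swapping carboxy for (pyrrolidin-1-yl)carbonyl gives a 1.1-fold higher number from compound 1 to compound 4 (0.03 log units; within the scatter) and so provides the first single-place step on the shared core. It shows that, for this pair, the hydroxy on the carbonyl carbon can give way to pyrrolidin-1-yl, with its five-membered non-aromatic ring and without the hydrogen-bond donor, while the read-out stays within the scatter. No supporting measurement accounts for this result.

On these data alone, what a methyl ester, a primary amide or a piperazin-1-yl amide at this carbonyl carbon would give remains open. One pair also leaves open whether the same swap would read alike on a compound carrying a different group elsewhere on the core.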